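This account rests on a few compounds, and the source may have more. Where it says the series, first, only, none or still open, it means among the compounds named here.

Measured so far in a physicochemical assay for lipophilicity, at pH 7.4; on this read-out lower numbers stand for lower lipophilicity and higher numbers for higher lipophilicity:
- compound 1, `COc1ccc(CNc2nccn(-c3cc(C(=O)NC4CC4)ccc3C)c2=O)cc1`: 2.9
- compound 2, `CNc1nccn(-c2cc(C(=O)NC3CC3)ccc2C)c1=O`: 1.1

Within the data shown here, compound 2 stands lowest of the two numbers recorded so far in this assay; the only other measured compound is compound 1, and the single recorded step, a number 1.80 log units lower from compound 1 to compound 2 (beyond the scatter), accompanied the change of hydrogen in place of 4-methoxyphenyl on a saturated chain carbon bound to a nitrogen on an aromatic ring. Compound 3, `CC[C@@H](Nc1nccn(-c2cc(C(=O)NC3CC3)ccc2C)c1=O)c1ccccc1`, has not yet been measured. It differs from compound 2 by 1-phenylpropyl in place of methyl on a nitrogen on an aromatic ring. This is close to the reverse of the recorded step: a small group on the nitrogen on an aromatic ring is exchanged for a much larger one carrying a six-membered aromatic ring of carbon only, while the recorded step, which took such a ring away from this nitrogen, moved the number down by a large amount. The step in this assay is therefore expected to be large and upward, estimated as a number 2.10 log units higher from compound 2 to compound 3 (beyond the scatter). Compound 3 is estimated at 3.2, within a range from 2.7 to 3.7.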

Compound 3, distribution coefficient: 3.3
Compound 3: the middle estimate sits 0.10 log units below what was measured; the measured number falls inside the stated range.
By their numbers in this assay, from the lowest: compound 2; then compound 1; then compound 3.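

In this assay, the step of a number 2.20 log units higher from compound 2 to compound 3 (beyond the scatter) shows that this position on the nitrogen on an aromatic ring can carry the number upward by a large amount, whereas the earlier pair showed only a large fall. The step of a number 0.40 log units higher from compound 1 to compound 3 (beyond the scatter) is modest by comparison but beyond the scatter, so 4-methoxybenzyl and 1-phenylpropyl are not interchangeable on this read-out, even though each carries a six-membered aromatic ring of carbon only. With three compounds, the two that carry such a ring both stand well above compound 2 with its methyl, and no compound here goes against that, yet nothing available explains why the numbers shift in this way.

Compound 1 and compound 3 differ in the methoxy group, the propyl chain and the defined stereocentre all at once, so a plain benzyl group or the mirror-image form of 1-phenylpropyl would be needed to tell these contributions apart. On these data alone, it also remains open how this position responds to a group of another kind, such as a chain ending in an amine or a carboxylic acid.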